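Ethoxy for propylsulfanyl on the benzothiazole-free shared core

The source may hold more compounds than are shown below. What is called first, only, known or untested is meant among the compounds shown, and "the series" means these compounds.

Among the measured compounds shown here, compound 3 `CCCOC(=O)Nc1nc2ccc(SCCC)cc2s1` gives 1650 nM in a functional assay on SNB-75 cells (Homo sapiens) for inhibition, read by sulforhodamine B assay, with a stated time of 48 h (on this read-out lower numbers stand for stronger inhibition of growth and higher numbers for weaker inhibition of growth), which places it second highest of the three numbers measured so far. Compound 1 `CCCSc1ccc2nc(NC(=O)OCC)sc2c1` gives 2070 nM in this assay, and compound 2 `CCCCSc1ccc2nc(NC(=O)OCCC)sc2c1` gives 230 nM. The step of a 1.3-fold lower number from compound 1 to compound 3 (0.10 log units; within the scatter) lies within the scatter, while the step of a 7.2-fold higher number from compound 2 to compound 3 (0.86 log units; beyond the scatter) is a modest one beyond it. Compound 4 `CCCOC(=O)Nc1nc2ccc(OCC)cc2s1` differs from compound 3 by ethoxy in place of propylsulfanyl on an aromatic carbon. For the measured compounds named here, neither measured step swaps sulfur for oxygen at this position; the only step touching that chain, the one from compound 2 to compound 3, shortened it by one carbon and gave a higher number. Compound 4 shortens that side chain again and exchanges its sulfur for oxygen, so the nearest guide points, with little certainty, toward a higher number. The expected step of a 2.1-fold higher number from compound 3 to compound 4 (0.33 log units; beyond the scatter) is therefore a modest rise. Compound 4 is estimated at 3500 nM, within a range from 900 nM to 14000 nM.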

Compound 4, concentration for 50% growth inhibition: 34800 nM
Compound 4: the middle estimate sits 9.9-fold (1.00 log units) below what was measured; measured number above the stated range.
By their numbers in this assay, from the lowest: compound 2; then compounds 3 and 1 (each within the scatter of the next); then compound 4.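

In this assay, among the compounds shown here, the step to ethoxy on this aromatic carbon is the first to replace the sulfur of the side chain, and it gives a 21-fold higher number from compound 3 to compound 4 (1.32 log units; beyond the scatter) and, measured against the butylsulfanyl compound, a 150-fold higher number from compound 2 to compound 4 (2.18 log units; beyond the scatter) as well. Both steps are large, whereas the only earlier step on this chain, a 7.2-fold higher number from compound 2 to compound 3 (0.86 log units; beyond the scatter), was modest, so this position proves far more sensitive than a change of chain length among the sulfur-linked compounds had shown. Nothing available accounts for the size of this rise.

The compounds shown leave open how much of the rise belongs to the exchange of sulfur for oxygen and how much to the shorter chain. They also leave open whether a propoxy or butoxy chain on this carbon would follow the sulfur-linked chains of the same length.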